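This account rests on a few compounds, and the source may have more. Where it says the series, first, only, none or still open, it means among the compounds named here.

Compound 1 `CCC1C(=O)N(C)c2cnc(Nc3ccc(S(=O)(=O)NCC(C)C)cc3)nc2N1c1ccn(C)n1` gives 311 nM in an assay for inhibition of serine/threonine-protein kinase PLK2 (Homo sapiens), read by FRET and Z'-LYTE, with a stated time of 1 h; on this read-out higher numbers stand for weaker inhibition and lower numbers for stronger inhibition.
Compound 2 `CC[C@@H]1C(=O)N(C)c2cnc(-n3ccc4cc(F)ccc43)nc2N1C1CCCC1` gives 969 nM in this assay.
Compound 3 `CCCNC(=O)c1ccc2c(ccn2-c2ncc3c(n2)N(C2CCCC2)[C@H](CC)C(=O)N3C)c1` gives 11.4 nM in this assay.

Among these three numbers, compound 1 stands second highest: compound 2 sits a little above it, beyond the scatter, while compound 3 lies well below both. Among the compounds with values here, the only step between compounds that differ in one place is an 85-fold lower number from compound 2 to compound 3 (1.93 log units; beyond the scatter), a change on an aromatic carbon that leaves the sulfonamide region of compound 1 untouched.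

Compound 4 `CCC1C(=O)N(C)c2cnc(Nc3ccc(S(N)(=O)=O)cc3)nc2N1c1ccn(C)n1` differs from compound 1 by hydrogen in place of isobutyl on a sulfonamide nitrogen. Within the data shown here, no measured pair in this set varies the substituent on the sulfonamide nitrogen, so the large step seen from compound 2 to compound 3 offers no direct guide, and the comparison between compound 1 and compound 4 rests on the structural change alone. With nothing in the data pointing either way, a step of at most modest size is expected, with no firm direction. Compound 4 is therefore expected to give about 400 nM, within a range from 150 nM to 1200 nM. This corresponds to an expected 1.3-fold higher number from compound 1 to compound 4 (0.11 log units; within the scatter).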

Compound 4, half-maximal inhibitory concentration: 121 nM
The estimate for compound 4 lay 3.3-fold (0.52 log units) above the measured number; measured number below the stated range.
By their numbers in this assay, from the lowest: compound 3; then compound 4; then compound 1; then compound 2.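

Within the data shown here, on the sulfonamide nitrogen, replacing isobutyl with hydrogen in this assay gives a 2.6-fold lower number from compound 1 to compound 4 (0.41 log units; beyond the scatter) and provides the first direct reading at this position. In this pair, the isobutyl group is not required for inhibition, and the plain sulfamoyl group gives the lower number of the two. No evidence is available to explain this step.

From the compounds shown here alone, with only hydrogen and isobutyl compared on this nitrogen, it remains open whether a methyl group, a longer chain or a chain ending in an amine or a carboxylic acid would give a number near either of these or outside both. Going by these compounds, whether the same replacement would give a similar step with other groups on the shared core also remains open.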